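A few compounds are considered here, and "the series" means these few. Any claim that something is new, unique, unknown or untested is made for them only; others in the source may bear on it.

In an ADME assay on a cell-free system (plasma, Homo sapiens) for metabolic stability, with a stated time of 90 min (on this read-out lower numbers stand for a less stable compound and higher numbers for a more stable compound), compound 1 `CCCC(=O)OCCCCCC(=O)N[C@H](C(=O)N1C[C@H](O)C[C@H]1C(=O)NCc1ccc(-c2scnc2C)cc1)C(C)(C)C` gives 13% and compound 2 `COCC(=O)OCCCCCC(=O)N[C@H](C(=O)N1C[C@H](O)C[C@H]1C(=O)NCc1ccc(-c2scnc2C)cc1)C(C)(C)C` gives 1%, the lower of the two numbers. Compound 3 `Cc1ncsc1-c1ccc(CNC(=O)[C@@H]2C[C@@H](O)CN2C(=O)[C@@H](NC(=O)CCCCCNC(=O)C2CCCCC2)C(C)(C)C)cc1` has not been measured, and its difference from compound 2 is (cyclohexylcarbonyl)amino in place of ((methoxymethyl)carbonyl)oxy on a saturated chain carbon, five bonds along the chain from a carbonyl carbon. For the measured compounds named here, the only measured step, a number 12 percentage points lower from compound 1 to compound 2 (beyond the scatter), came with methoxy in place of ethyl. Compound 1 and compound 2 both keep the oxy link, which leaves the present exchange untested. With compound 2 at 1%, little room remains downward, and a large but uncertain rise is expected. The expected change is a number 79 percentage points higher from compound 2 to compound 3 (beyond the scatter). For compound 3 the estimated value is 80%, within a range of 45% to 100%.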

Compound 3, percent of the compound remaining in the Homo sapiens assay: 168%
Compound 3: middle estimate off by 88 percentage points, on the low side; the whole stated range lies below it.
By their numbers in the Homo sapiens assay, from the lowest: compound 2; then compound 1; then compound 3.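

In the Homo sapiens assay, compound 2 gives 1%, compound 1 gives 13% and compound 3 gives 168%; (cyclohexylcarbonyl)amino on this saturated chain carbon gives a number 167 percentage points higher from compound 2 to compound 3 (beyond the scatter) and a number 155 percentage points higher from compound 1 to compound 3 (beyond the scatter), so the rise appears against both compounds with the oxy link and far exceeds a number 12 percentage points lower from compound 1 to compound 2 (beyond the scatter). In a physicochemical assay for lipophilicity, read by LC-MS, using the shake flask method, in phosphate buffer, with a stated time of 50 min, at pH 7.4 (on this read-out higher numbers stand for higher lipophilicity and lower numbers for lower lipophilicity), compound 2 gives 1.7 and compound 3 gives 1.4; the same exchange gives a number 0.30 log units lower from compound 2 to compound 3 (within the scatter), so the two compounds are not separated on this read-out. Nothing available explains the result.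

The amino link and the cyclohexyl ring enter together, and the compounds shown do not separate them. A (propylcarbonyl)amino group or a (cyclohexylcarbonyl)oxy group at this position would separate the two.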